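Flipping One Double Bond in Compound 3

The source may hold more compounds than are shown below. What is called first, only, known or untested is meant among the compounds shown, and "the series" means these compounds.

Values in a functional assay on HL-60 cells (Homo sapiens) for inhibition; a higher number here means a weaker inhibitor, a lower number a stronger inhibitor:
- compound 1 `COc1cc(/C=C/c2ccc(N(C)C)c([N+](=O)[O-])c2)cc(OC)c1OC`: > 5000 nM, a limit
- compound 2 `COc1cc(/C=C\c2ccc(N(C)C)c([N+](=O)[O-])c2)cc(OC)c1OC`: > 5000 nM, a limit
- compound 3 `COc1cc(/C=C/c2ccc(N(C)C)c(N)c2)cc(OC)c1OC`: 1520 nM

For the measured compounds named here, compound 3 carries the only true number in this assay, since the other two values are limits. Amino in place of nitro on an aromatic carbon accounts for an at least 3.2-fold lower number from compound 1 to compound 3 (0.51 log units; beyond the scatter), but that step concerns a different change from the one at issue here.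

The next compound is compound 4 `COc1cc(/C=C\c2ccc(N(C)C)c(N)c2)cc(OC)c1OC`, which has not yet been measured. Its difference from compound 3 is the two compounds have the same atoms and bonds and differ only in configuration as drawn: 1 of 1 stereo elements differ; a double bond is drawn E in compound 3 and Z in compound 4.

Going by the values given here, only one measured pair, with the fact that compounds 1 and 2 differ only in the configuration as drawn, shows this kind of change. That step is a step that the two limits leave unreadable from compound 1 to compound 2, and it gives no size because of the limit of > 5000 nM in this assay, at which 2 of the 3 values shown sit. Among the compounds with values here, no measured step therefore fixes the size or direction of this change, and any expectation is tentative. A lower number is expected, with wide uncertainty, and the expected step is a 10-fold lower number from compound 3 to compound 4 (1.01 log units; beyond the scatter).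

For compound 4 the estimated value is 150 nM, with an expected range from 15 nM to 2000 nM.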

Compound 4, half-maximal inhibitory concentration: 3 nM
Beside the measured number, compound 4's estimate is 50-fold (1.70 log units) above it, and the stated range ends above it.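

In this assay, the configuration of the double bond makes a large difference once the amino group is present: a 510-fold lower number from compound 3 to compound 4 (2.70 log units; beyond the scatter). The nitro pair could not show this, and the step from compound 1 to compound 2 cannot be read: the limit of > 5000 nM in this assay, at which 2 of the 4 values shown sit. Amino in place of nitro also gives a large step among the compounds with the double bond drawn Z, an at least 1600-fold lower number from compound 2 to compound 4 (3.22 log units; beyond the scatter), but whether this change really counts for more there than among those drawn E cannot be settled: the same change on two cores in this assay, an at least 3.2-fold lower number (0.51 log units; beyond the scatter) from compound 1 to compound 3 and an at least 1600-fold lower number (3.22 log units; beyond the scatter) from compound 2 to compound 4; the limit leaves it open whether they differ.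

Going by these compounds, it remains open whether the same large step from E to Z would appear with another group in place of the amino, such as a hydroxyl or an acetamide. The dimethylamino group is also unchanged in all the compounds shown, so what a methoxy group in its place would do remains open too.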